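Oxan-2-yl to oxan-3-yl: a small swap

A few compounds are considered here, and "the series" means these few. Any claim that something is new, unique, unknown or untested is made for them only; others in the source may bear on it.

In an ADME assay on MDCKII-LE cells (Canis lupus familiaris) for permeability, read by transwell migration, in the apical to basolateral direction (on this read-out higher numbers stand for higher permeability and lower numbers for lower permeability), compound 3 `NC(=O)[C@@H](CCC(F)(F)F)N(C[C@H]1CCCCO1)S(=O)(=O)c1ccc(Cl)cc1` gives 13.4 10^-6 cm/s as its reading. Compound 1 `CC1(C)C[C@@H](CN([C@H](CCC(F)(F)F)C(N)=O)S(=O)(=O)c2ccc(Cl)cc2)O1` gives 14.9 10^-6 cm/s here and compound 2 `CC1(C)CO[C@H]1CN([C@H](CCC(F)(F)F)C(N)=O)S(=O)(=O)c1ccc(Cl)cc1` gives 26.4 10^-6 cm/s here, so compound 3 sits within the usual scatter of both and no order among the three can be claimed.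

Compound 4 `NC(=O)[C@@H](CCC(F)(F)F)N(C[C@H]1CCCOC1)S(=O)(=O)c1ccc(Cl)cc1` has not been measured yet. It holds the same atoms as compound 3, joined differently: oxan-3-yl in place of oxan-2-yl on a saturated chain carbon bound to a sulfonamide nitrogen is the whole change, oxan-3-yl in place of oxan-2-yl on a saturated chain carbon bound to a sulfonamide nitrogen.

Among the measured compounds shown here, no measured step makes this exact swap. The closest evidence comes from other changes of the group at that place. Putting oxan-2-yl in place of 4,4-dimethyloxetan-2-yl gave a 1.1-fold lower number from compound 1 to compound 3 (0.05 log units; within the scatter) in this series, putting it in place of 3,3-dimethyloxetan-2-yl gave a 2.0-fold lower number from compound 2 to compound 3 (0.29 log units; within the scatter) in the same way, and exchanging the two dimethyloxetanyl groups gave a 1.8-fold higher number from compound 1 to compound 2 (0.25 log units; within the scatter) as well. All of these stayed inside the scatter, so no step beyond it is expected in this assay and no direction is favoured. The estimated move is a 1.0-fold higher number from compound 3 to compound 4 (0.02 log units; within the scatter) and nothing larger. Compound 4 is therefore estimated at 14 10^-6 cm/s with an expected range from 7.5 10^-6 cm/s to 26 10^-6 cm/s on repeat measurement.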

Compound 4, apparent permeability: 18.2 10^-6 cm/s
Compound 4: the middle estimate sits 1.3-fold (0.11 log units) below what was measured; the range from low to high includes it.
By their numbers in this assay, from the lowest: compounds 3, 1, 4 and 2 (each within the scatter of the next).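

Swapping oxan-2-yl for oxan-3-yl keeps the same atoms and only joins them differently, and in this assay this gives a 1.4-fold higher number from compound 3 to compound 4 (0.13 log units; within the scatter), the first direct reading of this exact change. Set against the two dimethyloxetanyl groups, oxan-3-yl gives a 1.5-fold lower number from compound 2 to compound 4 (0.16 log units; within the scatter) and a 1.2-fold higher number from compound 1 to compound 4 (0.09 log units; within the scatter), so its reading also stays close to theirs, and all four ring groups on a saturated chain carbon bound to a sulfonamide nitrogen remain within the scatter of one another, with no order among them that can be claimed. Nothing available explains these small differences or shows whether they are more than scatter.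

All four groups shown are saturated rings containing an oxygen, so it remains open whether a piperidine ring with its amine nitrogen, a carboxylic acid or a longer open chain at this place would produce a step beyond the scatter. Also open, as far as these compounds go, is whether reversing the defined stereocentre of oxan-3-yl would change the reading in this assay.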